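The compounds below may be only part of what the source reports. "The series", "measured", "known", "first", "only" and "open" are said of these compounds alone.

Compound 1, `CCc1cc2c(cc1C(=O)c1ccc(C(=O)O)cc1)C(C)(C)CCC2(C)C`: in an assay on isolated protein for binding affinity to retinoic acid receptor alpha (Homo sapiens) (on this read-out lower numbers stand for tighter binding and higher numbers for weaker binding), compound 1 gives > 1000 nM, which is a limit of the assay rather than a number.
Compound 2, `CCCc1cc2c(cc1C(=O)c1ccc(C(=O)O)cc1)C(C)(C)CCC2(C)C`: in this assay compound 2 gives > 1000 nM, again a limit of the assay and not a number.

Compound 2 therefore stands at the edge of what this assay can report, and the same holds for every value shown so far, since (the limit of > 1000 nM in this assay, at which 2 of the 2 values shown sit). Among the compounds with values here, the one step among the measured pair, a step that the two limits leave unreadable from compound 1 to compound 2, cannot be read as a size for this reason.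

Compound 3, `CC1(C)CCC(C)(C)c2cc(C(=O)c3ccc(C(=O)O)cc3)c(F)cc21`, arises from compound 2 through (fluoro in place of propyl on an aromatic carbon). No measured step speaks to this change in a readable way, so nothing shown points in either direction, and the most that can be said is that both measured compounds sit at the limit. The expected step is a step that the limit leaves unreadable from compound 2 to compound 3, and it is an expectation only. For compound 3 the estimate in this assay is 1500 nM, with a range from 200 nM to 10000 nM.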

Compound 3, dissociation constant: > 1000 nM
Compound 3: only a limit was reported; the forecaster's own chance of this, stated with the estimate: 60%; the middle value does not contradict the limit.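

In this assay compound 3 gives > 1000 nM, which is again a limit and not a number, so neither of its steps from compound 1 and compound 2 can be read: the limit of > 1000 nM in this assay, at which 3 of the 3 values shown sit.

The compounds shown leave open how tightly each one binds, and whether ethyl, propyl or fluoro on this aromatic carbon makes any difference.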